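A few compounds are considered here, and "the series" means these few. Any claim that something is new, unique, unknown or untested is made for them only; others in the source may bear on it.

Measured so far, in an assay on isolated protein for inhibition of histone acetyltransferase KAT2B (Homo sapiens), read by fluorescence, with a stated time of 10 min, tested at 50 uM; on this read-out lower numbers stand for less inhibition and higher numbers for more inhibition at the one concentration tested (going by the name of the read-out):
Compound 1 `COCCNC(=O)Cn1sc2ccccc2c1=O` gives 92%.
Compound 2 `O=C(Cn1sc2ccccc2c1=O)NCc1ccccn1` gives 91%.
Compound 3 `O=C(Cn1sc2ccccc2c1=O)Nc1nccs1` gives 97%.

All three share one core and differ only in the group carried on the amide-type nitrogen. In this assay compound 3 gives the highest of the three numbers, but the step of a number 5 percentage points higher from compound 1 to compound 3 (within the scatter) and the step of a number 6 percentage points higher from compound 2 to compound 3 (within the scatter) both lie within the scatter, so the three compounds cannot be told apart on these numbers.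

Compound 4 `CC(C)CNC(=O)Cn1sc2ccccc2c1=O` has not yet been measured. It differs from compound 3 in one place: isobutyl in place of 1,3-thiazol-2-yl on an amide-type nitrogen. Going by the values given here, the steps that bear on this change are those that also swap the group on that amide-type nitrogen: a number 5 percentage points higher from compound 1 to compound 3 (within the scatter), a number 6 percentage points higher from compound 2 to compound 3 (within the scatter) and a number 1 percentage points lower from compound 1 to compound 2 (within the scatter), all within the scatter. A 2-methoxyethyl chain, a (pyridin-2-yl)methyl group and a 1,3-thiazol-2-yl ring on this nitrogen give numbers that cannot be separated, so an isobutyl chain there is expected to change little as well. The expected step is a number 7 percentage points lower from compound 3 to compound 4 (within the scatter), that is, none beyond the scatter. Compound 4 is therefore estimated at 90%, within a range from 75% to 99%.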

Compound 4, a percentage reported as inhibition, at one concentration (the size of the read-out at that concentration, not a potency): 95%
Compound 4: middle estimate off by 5 percentage points, on the low side, within the range that was stated.
By their numbers in this assay, from the lowest: compounds 2, 1, 4 and 3 (each within the scatter of the next).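

Going by these compounds alone, compound 4 is the first in this set whose group on the amide-type nitrogen holds only carbon atoms, with no ring and no hydrogen-bond acceptors. Even so, this assay shows no separation from the thiazole compound (a number 2 percentage points lower from compound 3 to compound 4 (within the scatter)) or from the other two (a number 4 percentage points higher from compound 2 to compound 4 (within the scatter); a number 3 percentage points higher from compound 1 to compound 4 (within the scatter)), so on these numbers neither a ring nor a hetero atom in this group is needed for high inhibition at the one concentration tested. Nothing measured here explains why these four numbers sit so close together.

On these data alone, whether a carboxylic acid, an amine or a much longer alkyl chain on this nitrogen would fit the same picture remains open. A reading at one concentration is also not a potency, so real differences among these four compounds could still appear at lower concentrations.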